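From 3-Methylphenyl to 4-Ethylphenyl on the Sulfonamide Nitrogen

A few compounds are considered here, and "the series" means these few. Any claim that something is new, unique, unknown or untested is made for them only; others in the source may bear on it.

In a functional assay on MCF7 cells (Homo sapiens) for inhibition, read by CCK-8 assay, with a stated time of 72 h (on this read-out lower numbers stand for stronger inhibition and higher numbers for weaker inhibition), compound 1 (`O=C(/C=C/c1cccnc1)NCCCCCCc1cccc(S(=O)(=O)Nc2ccccc2)c1`) gives 0.63 nM, compound 2 (`Cc1ccccc1NS(=O)(=O)c1cccc(CCCCCCNC(=O)/C=C/c2cccnc2)c1`) gives 0.226 nM and compound 3 (`Cc1cccc(NS(=O)(=O)c2cccc(CCCCCCNC(=O)/C=C/c3cccnc3)c2)c1`) gives 4 nM, the highest number of the three. Compound 4 (`CCc1ccc(NS(=O)(=O)c2cccc(CCCCCCNC(=O)/C=C/c3cccnc3)c2)cc1`) has not yet been measured. It carries 4-ethylphenyl in place of 3-methylphenyl on a sulfonamide nitrogen.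

Going by the values given here, three measured steps bear on this change. Adding a methyl to the aromatic ring moves the number in opposite directions, with a 2.8-fold lower number from compound 1 to compound 2 (0.45 log units; beyond the scatter) and a 6.3-fold higher number from compound 1 to compound 3 (0.80 log units; beyond the scatter). Exchanging 2-methylphenyl for 3-methylphenyl alone gives an 18-fold higher number from compound 2 to compound 3 (1.25 log units; beyond the scatter), a large step. Among the compounds with values here, the aryl group on the sulfonamide nitrogen therefore clearly matters, but no measured compound carries an ethyl group or a 4-substituted phenyl, so the direction rests on weak evidence. Compound 3 stands above the unsubstituted compound 1 at 0.63 nM, and leaving the 3-methylphenyl group is expected to recover part of that gap. An expected step of a 2.7-fold lower number from compound 3 to compound 4 (0.43 log units; beyond the scatter) is estimated, modest in size and towards a lower number. For compound 4 the estimate is 1.5 nM, with an expected range from 0.3 nM to 7 nM.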

Compound 4, half-maximal inhibitory concentration: 3.64 nM
Beside the measured number, compound 4's estimate is 2.4-fold (0.39 log units) below it; measured number inside the range.
By their numbers in this assay, from the lowest: compound 2; then compound 1; then compounds 4 and 3 (each within the scatter of the next).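

In this assay, 4-ethylphenyl in place of 3-methylphenyl on the sulfonamide nitrogen gives a 1.1-fold lower number from compound 3 to compound 4 (0.04 log units; within the scatter) and so does not separate the two groups, which shows that this position can tolerate this exchange with no measurable change in the number. Both groups stand on the same side of the unsubstituted phenyl: adding an ethyl group to that phenyl gives a 5.8-fold higher number from compound 1 to compound 4 (0.76 log units; beyond the scatter) and resembles the methyl step that gave a 6.3-fold higher number from compound 1 to compound 3 (0.80 log units; beyond the scatter) while the 2-methylphenyl group of compound 2 goes against this pattern. The large gap for 4-ethylphenyl in place of 2-methylphenyl, a 16-fold higher number from compound 2 to compound 4 (1.21 log units; beyond the scatter) makes compound 2 the one clear departure among the substituted compounds, and nothing given here explains these differences.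

Compound 4 differs from compound 3 in both the alkyl group and its place on the ring, so the compounds shown leave open what each of these contributes alone. They also leave open how the number would respond to a phenyl ring carrying a methoxy group, a chlorine atom or an amine on the sulfonamide nitrogen.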